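The source may report more compounds than this note shows. Statements on the series, on what has been measured and on what is new or still open speak of the compounds shown alone.

The series shares one core, set out in compound 1 `COC(=O)CC/C(C)=C/Cc1c(OC)c(C)c2c(c1OCC#CCN1CCC(Cc3ccccc3)CC1)C(=O)OC2` and compound 2 `COC(=O)CC/C(C)=C/Cc1c(OC)c(C)c2c(c1OCC#CCN1CCN(c3ccc(O)cc3)CC1)C(=O)OC2`, which differ only in the amine at the end of the alkyne-linked chain. In a functional assay on FaDu cells (Homo sapiens) for inhibition, read by sulforhodamine B assay (a lower number here means a stronger inhibitor, a higher number a weaker inhibitor), compound 1 gives only a limit, > 50000 nM. In this assay compound 2 likewise gives only a limit, > 50000 nM, so compound 2 stands at the limit rather than at a number; indeed (the limit of > 50000 nM in this assay, at which 2 of the 2 values shown sit).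

Compound 3 `COC(=O)CC/C(C)=C/Cc1c(OC)c(C)c2c(c1OCC#CCN1CCN(Cc3ccc(Cl)cc3)CC1)C(=O)OC2` is not yet measured. It differs from compound 2 by 4-chlorobenzyl in place of 4-hydroxyphenyl on an amine nitrogen in a ring.

Among the compounds with values here, no step between measured compounds is available, and both known values sit at the limit. Compound 3 is therefore expected to show a step that the limit leaves unreadable from compound 2 to compound 3 from compound 2 that is none beyond the scatter. Compound 3 is estimated at 60000 nM in this assay, within a range from 10000 nM to 300000 nM, most likely again reported only as a limit.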

Compound 3, half-maximal inhibitory concentration: > 50000 nM
Compound 3: no number, only a limit; the forecaster's own chance of this, stated with the estimate: 75%; the middle value is on the limit's open side.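

In this assay compound 3 gives only a limit, > 50000 nM. Within the data shown here, compound 2 also stands at a limit, so no step from compound 2 to compound 3 can be read. The compounds shown leave open how any of these amines changes inhibition, because all sit at one value: the limit of > 50000 nM in this assay, at which 3 of the 3 values shown sit.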